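A few compounds are considered here, and "the series" means these few. Any claim that something is new, unique, unknown or untested is made for them only; others in the source may bear on it.

Measured in a functional assay on P388 cells (Mus musculus) for cytotoxicity; a lower number here means a stronger inhibitor, a higher number a weaker inhibitor:
compound 1, `COc1ccc(C[C@H]2C(=O)N[C@@H](C)C(=O)N(C)[C@H]3Cc4ccc(cc4)Oc4cc(ccc4OC)C[C@@H](C(=O)N[C@H](C)C(=O)N[C@@H](CCC(=O)O)C(=O)N2C)N(C)C3=O)cc1`, gives 219 nM
compound 2, `COc1ccc(C[C@H]2C(=O)N[C@@H](C)C(=O)N(C)[C@H]3Cc4ccc(cc4)Oc4cc(ccc4OC)C[C@@H](C(=O)N[C@H](C)C(=O)N[C@@H](CCCO)C(=O)N2C)N(C)C3=O)cc1`, gives 174 nM
compound 3, `COc1ccc(C[C@H]2C(=O)N[C@@H](C)C(=O)N(C)[C@H]3Cc4ccc(cc4)Oc4cc(ccc4OC)C[C@@H](C(=O)N[C@H](C)C(=O)N[C@@H](CC(=O)O)C(=O)N2C)N(C)C3=O)cc1`, gives 1200 nM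

Compound 4, `COc1ccc(C[C@H]2C(=O)N[C@@H](C)C(=O)N(C)[C@H]3Cc4ccc(cc4)Oc4cc(ccc4OC)C[C@@H](C(=O)N[C@H](C)C(=O)N[C@@H](CCO)C(=O)N2C)N(C)C3=O)cc1`, has not yet been measured in this assay. It is made from compound 3 by one change, (hydroxymethyl in place of carboxy on a saturated chain carbon bound to a saturated ring carbon). The same kind of change has already been measured once, from compound 1 to compound 2: hydroxymethyl in place of carboxy on a saturated chain carbon, two bonds along the chain from a saturated ring carbon. That step gave a 1.3-fold lower number from compound 1 to compound 2 (0.10 log units; within the scatter), so on that chain the two groups read as interchangeable. The two places are not the same word for word: in the first pair the change sits on a saturated chain carbon, two bonds along the chain from a saturated ring carbon, while in compound 3 and compound 4 it sits on a saturated chain carbon bound to a saturated ring carbon. The cores of compound 1 and compound 3 differ by carboxy in place of carboxymethyl on a saturated chain carbon bound to a saturated ring carbon, a shortening that gave a 5.5-fold higher number from compound 1 to compound 3 (0.74 log units; beyond the scatter), and compound 2 to compound 3 gave a 6.9-fold higher number from compound 2 to compound 3 (0.84 log units; beyond the scatter).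

Among the measured compounds shown here, with only one earlier example, the expectation for compound 4 rests on compound 1 and compound 2, whose step a 1.3-fold lower number from compound 1 to compound 2 (0.10 log units; within the scatter) stayed within the scatter, so a step of similar small size is expected here: a 1.2-fold lower number from compound 3 to compound 4 (0.08 log units; within the scatter). The shorter chain is a difference, so the range kept around the estimate is wide. Compound 4 is expected to give about 1000 nM in this assay, between 400 nM and 2500 nM.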

Compound 4, half-maximal inhibitory concentration: 60.3 nM
Compound 4: the middle estimate sits 17-fold (1.22 log units) above what was measured; the measured number lies below the stated range.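

Swapping carboxy for hydroxymethyl did not carry over from one core to the other in this assay: the same change on two cores in this assay, a 1.3-fold lower number (0.10 log units; within the scatter) from compound 1 to compound 2 and a 20-fold lower number (1.30 log units; beyond the scatter) from compound 3 to compound 4, 16-fold (1.20 log units) apart, beyond the scatter of two such steps. On the shorter chain the result is a 20-fold lower number from compound 3 to compound 4 (1.30 log units; beyond the scatter), and compound 4 also ends up ahead of the longer-chain compounds, with a 2.9-fold lower number from compound 2 to compound 4 (0.46 log units; beyond the scatter) and a 3.6-fold lower number from compound 1 to compound 4 (0.56 log units; beyond the scatter), which gives it the lowest number of the four compounds shown. Among the compounds shown here, this shows that a near-neutral swap on one chain length cannot be assumed to stay near-neutral on another, but with only two pairs it does not show why the steps differ or what the same swap would do on any further core.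

The compounds shown leave open how an amine or an amide at the end of the same chain would compare with the carboxy and hydroxy ends. They also leave open whether a longer chain ending in hydroxy or carboxy would follow the same direction as these compounds.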